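This account rests on a few compounds, and the source may have more. Where it says the series, first, only, none or still open, it means among the compounds named here.

Compound 1 `COc1cc2nc(N3CCCN(C(=O)N4CCOCC4)CC3)cc(N)c2c(-c2ccccc2)c1OC` was examined in an in vivo ADME assay on the whole organism for pharmacokinetics, with Canis familiaris (Canis lupus familiaris) as the target, at a dose of 0.5 mg/kg by the intravenous route (on this read-out higher numbers stand for wider distribution into tissues and lower numbers for narrower distribution), where compound 1 gives 2.8 L/kg. Among the compounds with values here, the only other measured compound, compound 2 `COc1cc2nc(N3CCc4ncccc4C3)nc(N)c2c(-c2ncccn2)c1OC`, gives 5.1 L/kg in this assay, and the two values lie within the scatter of each other, so the numbers themselves set no order between them. Compound 3 `COc1cc2nc(N3CCCN(C(=O)N4CCOCC4)CC3)cc(N)c2c(-c2ccc(F)cc2)c1OC` differs from compound 1 in one place: fluoro in place of hydrogen on an aromatic carbon. Within the data shown here, no pair of measured compounds separated by a single change is available here, so the size of this step must be judged from the change alone. Fluoro in place of hydrogen on the phenyl group is a modest alteration, and in this assay the expected step is a 1.1-fold higher number from compound 1 to compound 3 (0.03 log units; within the scatter), small and in no particular direction beyond the scatter. Compound 3 is therefore estimated at 3 L/kg, with a range from 1.7 L/kg to 5.3 L/kg.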

Compound 3, volume of distribution in the Canis familiaris assay: 4.8 L/kg
Compound 3: the middle estimate sits 1.6-fold (0.20 log units) below what was measured, and the stated range covers the measured number.
By their numbers in the Canis familiaris assay, from the lowest: compounds 1, 3 and 2 (each within the scatter of the next).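

Within the data shown here, in the Canis familiaris assay, compound 1 gives 2.8 L/kg and compound 3 gives 4.8 L/kg; phenyl to 4-fluorophenyl gives the first step here that differs in one place, a 1.7-fold higher number from compound 1 to compound 3 (0.23 log units; within the scatter), so fluoro in place of hydrogen at this position leaves the two compounds indistinguishable on volume of distribution. In a physicochemical assay for lipophilicity, in phosphate buffer, at pH 7.4 (on this read-out higher numbers stand for higher lipophilicity and lower numbers for lower lipophilicity), compound 1 gives 1.8 and compound 3 gives 1.8, and the same change gives no change at the digits printed from compound 1 to compound 3 (within the scatter), so neither read-out separates the pair. No measurement at hand bears on the reason for these readings.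

On these data alone, whether a larger group in the same place, such as an amine, a carboxylic acid or a longer alkyl chain, would give a step beyond the scatter remains open. This single pair also cannot show whether fluoro in place of hydrogen would give a similar step in a compound with a different core.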